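From Trimethoxyphenyl to Dihydroxyphenyl: Expecting Little Change

The source may report more compounds than this note shows. Statements on the series, on what has been measured and on what is new or still open speak of the compounds shown alone.

In a functional assay on A549 cells (Homo sapiens) for cytotoxicity, read by MTT assay, with a stated time of 72 h (on this read-out higher numbers stand for weaker inhibition and lower numbers for stronger inhibition), compound 1 `COc1cc2ncnc(Nc3ccc(F)c(Cl)c3)c2cc1NC(=O)N/N=C/c1cccc(Cl)c1Cl` gives 35300 nM and compound 2 `COc1cc2ncnc(Nc3ccc(F)c(Cl)c3)c2cc1NC(=O)N/N=C/c1ccc(OC)c(OC)c1OC` gives 32800 nM. These two values lie within the scatter of each other, so compound 2 cannot be ranked against compound 1. Compound 3 `COc1cc2ncnc(Nc3ccc(F)c(Cl)c3)c2cc1NC(=O)N/N=C/c1ccc(O)cc1O` carries 2,4-dihydroxyphenyl in place of 2,3,4-trimethoxyphenyl on a carbon with a double bond to nitrogen. Going by the values given here, the only measured step that bears on this change is at the same place, where 2,3-dichlorophenyl gave way to 2,3,4-trimethoxyphenyl: a 1.1-fold lower number from compound 1 to compound 2 (0.03 log units; within the scatter). Among the compounds with values here, no measured compound carries hydroxyl groups, so this single step is a limited guide. In this assay, the expected change is none beyond the scatter, an estimated 1.1-fold lower number from compound 2 to compound 3 (0.04 log units; within the scatter). For compound 3 the estimated value is 30000 nM, with an expected range from 10000 nM to 80000 nM.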

Compound 3, half-maximal inhibitory concentration: 31400 nM
Estimate against measurement, compound 3: 1.0-fold (0.02 log units) below, within the range that was stated.
By their numbers in this assay, from the lowest: compounds 3, 2 and 1 (each within the scatter of the next).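

In this assay the new result gives a 1.0-fold lower number from compound 2 to compound 3 (0.02 log units; within the scatter) for 2,4-dihydroxyphenyl in place of 2,3,4-trimethoxyphenyl, and a 1.1-fold lower number from compound 1 to compound 3 (0.05 log units; within the scatter) for 2,4-dihydroxyphenyl in place of 2,3-dichlorophenyl. Hydroxyl groups, the hydrogen-bond donors absent from the two earlier groups, therefore join chloro and methoxy groups on this ring, and the three compounds still cannot be told apart in this read-out. Nothing available explains this sameness.

Going by these compounds alone, every group seen at this position so far is a substituted phenyl ring, so it remains open whether any group here can move the number beyond the scatter. An amine or a carboxylic acid on that ring, or a longer alkyl chain in place of the ring, would test this more widely.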